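Exchanging the Hydroxyalkyl Group on a Urea Carbonyl

This account rests on a few compounds, and the source may have more. Where it says the series, first, only, none or still open, it means among the compounds named here.

Measured so far:
compound 1, `COc1cc(NC(C)CCCNC(=O)NNC(=O)N(CCO)CCO)c2ncccc2c1`: 29000 nM
compound 2, `O=C(NC(c1ccccc1)c1ccc(Cl)cc1)n1nnc2ccccc21`: 42000 nM

Of the compounds shown here, two have been tested in a functional assay on MCF7 cells (Homo sapiens) for inhibition, read by MTT assay, with a stated time of 4 days; on this read-out higher numbers stand for weaker inhibition and lower numbers for stronger inhibition. In this assay compound 1 gives 29000 nM, and compound 2 gives 42000 nM. Compound 1 has the lower of the two numbers, but the gap between them lies within the usual scatter of repeated measurements, so the two compounds cannot be ranked against each other; both are weak inhibitors on this read-out.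

Compound 3, `COc1cc(NC(C)CCCNC(=O)NNC(=O)NCCCO)c2ncccc2c1`, has not yet been measured. It differs from compound 1 in a single place: (3-hydroxypropyl)amino in place of bis(2-hydroxyethyl)amino on a carbonyl carbon. The rest of the molecule, including the core of compound 1, is left untouched. Among the compounds with values here, no measured pair of compounds shows a change of this kind, so there is no comparison to lean on; the two groups are both short chains carrying an alcohol, and the change is a modest one.

The expected step of a 1.0-fold higher number from compound 1 to compound 3 (0.01 log units; within the scatter) is none beyond the scatter. Compound 3 is therefore estimated at 30000 nM, with a range from 10000 nM to 90000 nM.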

Compound 3, half-maximal inhibitory concentration: 13000 nM
For compound 3 the middle estimate is 2.3-fold (0.36 log units) above the measured one, and the stated range covers the measured number.
By their numbers in this assay, from the lowest: compound 3; then compounds 1 and 2 (each within the scatter of the next).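

In this assay the group on this carbonyl carbon, whose other neighbour is an amide-type nitrogen, turns out to matter: (3-hydroxypropyl)amino in place of bis(2-hydroxyethyl)amino gives a 2.2-fold lower number from compound 1 to compound 3 (0.35 log units; beyond the scatter) and so moves the number by a modest step while the core of compound 1 stays untouched. The change is not a single variable, since the entering group has 5 heavy atoms in place of 7 and 1 hydrogen-bond acceptor in place of 2, with both groups carrying 2 hydrogen-bond donors, and this one pair cannot separate these differences. Nothing measured here explains why the number moves.

On these data alone, what stays open is whether the alcohol, the length of the chain or the loss of the second chain governs this step, and a propylamino group with no alcohol, a 4-hydroxybutylamino group with a longer chain or a 2-hydroxyethylamino group with a shorter one would each test a part of that. As far as these compounds go, a carboxylic acid or an amine at the end of the chain would show whether the terminal alcohol can be exchanged at all, and with compound 3 at 13000 nM it also remains unknown whether any change here can go much further.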